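This account rests on a few compounds, and the source may have more. Where it says the series, first, only, none or still open, it means among the compounds named here.

Measured in a functional assay on HCT-116 cells (Homo sapiens) for antiproliferative activity, read by MTT assay, with a stated time of 24 h; on this read-out lower numbers stand for stronger inhibition and higher numbers for weaker inhibition:
Compound 1 `COc1ccc(C(=O)/C=C/c2ccc(-c3ccccc3)cc2)c2c1C=CC(C)(C)O2`: > 10000 nM, a limit of the assay.
Compound 2 `CCN(CC)c1ccc(/C=C/C(=O)c2ccc(OC)c3c2OC(C)(C)C=C3)cc1`: 620 nM.
Compound 3 `COc1ccc(C(=O)/C=C/c2ccc(N3CCCC3)cc2)c2c1C=CC(C)(C)O2`: 8590 nM.

Of the two actual numbers, compound 3 holds the higher, and the gap is large: a 14-fold higher number from compound 2 to compound 3 (1.14 log units; beyond the scatter). Compound 4 `COc1ccc(C(=O)/C=C/c2ccc(C(F)(F)F)cc2)c2c1C=CC(C)(C)O2` changes one group of compound 3: trifluoromethyl in place of pyrrolidin-1-yl on an aromatic carbon. Two further steps bear on this place. Diethylamino in place of phenyl gave a large change, an at least 16-fold lower number from compound 1 to compound 2 (1.20 log units; beyond the scatter). Pyrrolidin-1-yl in place of phenyl gave only an at least 1.1-fold lower number from compound 1 to compound 3 (0.06 log units; that floor lies within the scatter), and this step is the nearest guide, since phenyl, like trifluoromethyl, carries no nitrogen. No step beyond the scatter is therefore expected in this assay, at most a slight rise: a 1.3-fold higher number from compound 3 to compound 4 (0.11 log units; within the scatter). For compound 4 the estimated value is 11000 nM, with an expected range of 4000 nM to 30000 nM.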

Compound 4, half-maximal inhibitory concentration: > 10000 nM
Compound 4: only a limit was reported; the forecaster's own chance of this, stated with the estimate: 50%; the middle value is on the limit's open side.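

In this assay compound 4 gives only a limit, so trifluoromethyl in place of pyrrolidin-1-yl reads as an at least 1.1-fold higher number from compound 3 to compound 4 (0.06 log units; that floor lies within the scatter), and this floor does not separate the two groups. Trifluoromethyl in place of diethylamino gives an at least 16-fold higher number from compound 2 to compound 4 (1.20 log units; beyond the scatter), which leaves diethylamino as the only group shown here with a measured number well clear of the limit. The values of compound 1 and compound 4 are both limits, and the step between them cannot be read: the limit of > 10000 nM in this assay, at which 2 of the 4 values shown sit.

From the compounds shown here alone, how far compound 4 lies past its limit stays open. So does whether dimethylamino or morpholin-4-yl at this place would track diethylamino or pyrrolidin-1-yl.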